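Swapping the chain end of compound 3

The source may hold more compounds than are shown below. What is called first, only, known or untested is meant among the compounds shown, and "the series" means these compounds.

In an ADME assay on BJ cells (Homo sapiens) for cytotoxicity, with a stated time of 72 h (on this read-out higher numbers stand for an effect only at larger amounts of compound and lower numbers for an effect already at smaller amounts), compound 3 `COc1cc2ncnc(-n3nc(-c4ccccn4)nc3N)c2cc1OCCNC(=O)OC(C)(C)C` gives only a limit (> 15000 nM). Compound 1 `COCCOc1cc2c(-n3nc(-c4ccccn4)nc3N)ncnc2cc1OC` also gives only a limit (> 13000 nM). Compound 2 `COc1cc2ncnc(-n3nc(-c4ccccn4)nc3N)c2cc1OCCCNC(=O)OC(C)(C)C` likewise gives only a limit (> 12000 nM). So compound 3 has no exact position among these three, and none can be ranked against the others.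

Compound 4 `COc1cc2ncnc(-n3nc(-c4ccccn4)nc3N)c2cc1OCCCNC(=O)OCC(F)(F)F` carries (((2,2,2-trifluoroethoxy)carbonyl)amino)methyl in place of (tert-butoxycarbonyl)amino on a saturated chain carbon, two bonds along the chain from an oxygen on an aromatic ring.

Three measured changes at this same place bear on it. They are a step that the two limits leave unreadable from compound 1 to compound 2 and a step that the two limits leave unreadable from compound 1 to compound 3 and a step that the two limits leave unreadable from compound 2 to compound 3 and none of them has a readable size. Each of these different groups still ended at a limit, so a similar outcome is the expectation here. Resting on compound 3 (> 15000 nM) no step beyond the scatter is expected in this assay and the estimated change is an at least 1.0-fold lower number from compound 3 to compound 4 (0.02 log units; that floor lies within the scatter) for this swap. Compound 4 is estimated at 14000 nM with an expected range of 6000 nM to 30000 nM in this measurement.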

Compound 4, half-maximal effective concentration: > 11000 nM
Compound 4: no number, only a limit; the forecaster's own chance of this, stated with the estimate: 80%; the middle value lies beyond the limit too.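

In this assay compound 4 gives only a limit, > 11000 nM. Compound 1, compound 2 and compound 3 also gave only limits, so none of their steps to compound 4 can be read. The compounds shown leave open the concentration at which any of the four would reach a half-maximal effect, and how they rank.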